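This account rests on a few compounds, and the source may have more. Where it says the series, first, only, none or still open, it means among the compounds named here.

In an ADME assay on HEK293 cells (Homo sapiens) for cytotoxicity, read by resazurin assay, with a stated time of 72 h (on this read-out higher numbers stand for lower toxicity in this test and lower numbers for higher toxicity in this test), compound 1 `CCc1cccc(CNC(=O)c2nc3cccc(COc4ccc(CC(=O)O)cc4)c3c(=O)[nH]2)c1` gives > 20000 nM, which is a limit of the assay and not a number. Compound 2 `CCc1cccc(CNC(=O)c2nc3cccc(COc4ccc(C(=O)O)cc4)c3c(=O)[nH]2)c1` gives > 20000 nM, which is likewise a limit. The whole picture so far is the limit of > 20000 nM in this assay, at which 2 of the 2 values shown sit. For the measured compounds named here, the one measured step is a step that the two limits leave unreadable from compound 1 to compound 2, so it offers no size to carry forward.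

Compound 3 `CCc1cccc(CNC(=O)c2nc3cccc(COCc4ccc(C(=O)O)cc4)c3c(=O)[nH]2)c1` has 4-carboxybenzyl in place of 4-carboxyphenyl on an oxygen on a saturated carbon. The expectation for compound 3 rests on the limit of compound 2, > 20000 nM. No step beyond the scatter is expected in this assay, and a report of the limit alone is the likeliest result. The expected move is a step that the limit leaves unreadable from compound 2 to compound 3. The estimate for compound 3 is 25000 nM, with an expected range from 15000 nM to 50000 nM.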

Compound 3, half-maximal cytotoxic concentration: > 40000 nM
Compound 3: no number, only a limit; the forecaster's own chance of this, stated with the estimate: 90%; at least 1.6-fold (0.20 log units) between middle value and limit.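

Compound 3 gives > 40000 nM, which is a limit and not a number. For the compounds shown here, compound 1, compound 2 and compound 3 all stand at limits, so no step among them can be read. From the compounds shown here alone, whether any of them has a measurable cytotoxic concentration in this assay stays open.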